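Chain length and myeloperoxidase inhibition in a three-member series

This account rests on a few compounds, and the source may have more. Where it says the series, first, only, none or still open, it means among the compounds named here.

Measured so far:
compound 1 `NCc1c[nH]c2ccc(F)cc12`: 900 nM
compound 2 `NCCCc1c[nH]c2ccc(F)cc12`: 50 nM
compound 3 `NCCCCc1c[nH]c2ccc(F)cc12`: 15 nM

All three compounds share one core and differ only in the length of the amine-bearing chain. In an assay on urine for inhibition of Myeloperoxidase (Homo sapiens) (on this read-out higher numbers stand for weaker inhibition and lower numbers for stronger inhibition), compound 1 gives 900 nM, compound 2 gives 50 nM and compound 3 gives 15 nM. The change 2-aminoethyl in place of amino on a saturated chain carbon bound to an aromatic carbon gave an 18-fold lower number from compound 1 to compound 2 (1.26 log units; beyond the scatter). Going by the values given here, the change 3-aminopropyl in place of amino on a saturated chain carbon bound to an aromatic carbon gave a 60-fold lower number from compound 1 to compound 3 (1.78 log units; beyond the scatter), and the single further step a 3.3-fold lower number from compound 2 to compound 3 (0.52 log units; beyond the scatter) is smaller than the first extension but still beyond the scatter. Compound 3 thus stands lowest of the three, with its steps to both others beyond the scatter.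

Compound 4 `NCCCCCCc1c[nH]c2ccc(F)cc12` carries the change (2-aminoethyl in place of amino on a saturated chain carbon, four bonds along the chain from an aromatic carbon). This is the same kind of change as from compound 1 to compound 2, with the difference that there the two carbons entered on a saturated chain carbon bound to an aromatic carbon, whereas here they enter four bonds along the chain from an aromatic carbon. The gain per added carbon has shrunk along the series, from an 18-fold lower number from compound 1 to compound 2 (1.26 log units; beyond the scatter) to a 3.3-fold lower number from compound 2 to compound 3 (0.52 log units; beyond the scatter), so a further two carbons are expected to give at most a small step, a 1.9-fold lower number from compound 3 to compound 4 (0.27 log units; within the scatter), with a real chance of no gain at all. Compound 4 is therefore estimated at 8 nM, with a range from 2.5 nM to 40 nM.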

Compound 4, half-maximal inhibitory concentration: 260 nM
Compound 4: middle estimate off by 33-fold (1.51 log units), on the low side; measured number above the stated range.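

Carried onto the chain of compound 3, the change to 2-aminoethyl in place of amino, four bonds along the chain from an aromatic carbon, gave a 17-fold higher number from compound 3 to compound 4 (1.24 log units; beyond the scatter) in this assay, so the gain seen on the shortest chain did not carry over and the step reversed in direction: the same change on two cores in this assay, an 18-fold lower number (1.26 log units; beyond the scatter) from compound 1 to compound 2 and a 17-fold higher number (1.24 log units; beyond the scatter) from compound 3 to compound 4, 310-fold (2.49 log units) apart, beyond the scatter of two such steps.
The change to 3-aminopropyl behaves the same way, three bonds along the chain from an aromatic carbon, with a 5.2-fold higher number from compound 2 to compound 4 (0.72 log units; beyond the scatter) set against the large gain seen when the same group entered on the shortest chain: the same change on two cores in this assay, a 60-fold lower number (1.78 log units; beyond the scatter) from compound 1 to compound 3 and a 5.2-fold higher number (0.72 log units; beyond the scatter) from compound 2 to compound 4, 310-fold (2.49 log units) apart, beyond the scatter of two such steps.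
So the effect of a chain extension in this series depends on the chain it starts from, with compound 3 lowest of the four, but these steps do not show where the turn lies along the chain, and they say nothing about any other ring core, as all four compounds share one core.

Open, on these data alone, is how a 5-aminopentyl chain on the shared core would read out, which would place the turn more closely.
Also open, as far as these compounds go, is whether the same dependence on length holds with a dimethylamino group or a carboxylic acid at the chain end in place of the primary amine.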